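Swapping one five-membered ring for another on the shared core

The compounds below may be only part of what the source reports. "The series", "measured", "known", "first", "only" and "open" are said of these compounds alone.

Three compounds share a core and differ only in the group on a saturated chain carbon bound to an aromatic carbon and a saturated chain carbon. In an ADME assay on microsomes from liver (Homo sapiens) for metabolic stability (on this read-out higher numbers stand for a longer-lived compound and lower numbers for a shorter-lived compound), compound 1 `CC(C)NC(=O)CC(c1ccc(-c2ccc3cccc(F)c3c2)[nH]c1=O)C(C)C` gives 0.32 h, compound 2 `CC(C)C(/C=C1\CCNC1=O)c1ccc(-c2ccc3cccc(F)c3c2)[nH]c1=O` gives 0.713 h and compound 3 `CC(C)C(c1cnc(N)s1)c1ccc(-c2ccc3cccc(F)c3c2)[nH]c1=O` gives 0.178 h. Compound 3 holds the lowest of the three numbers, yet a 1.8-fold lower number from compound 1 to compound 3 (0.25 log units; within the scatter), so compound 1 and compound 3 cannot be told apart, whereas a 4.0-fold lower number from compound 2 to compound 3 (0.60 log units; beyond the scatter). Compound 4 `Cc1c[nH]c(C(c2ccc(-c3ccc4cccc(F)c4c3)[nH]c2=O)C(C)C)n1` carries 4-methyl-1H-imidazol-2-yl in place of 2-amino-1,3-thiazol-5-yl on a saturated chain carbon bound to an aromatic carbon and a saturated chain carbon. Among the compounds with values here, no measured step exchanges one five-membered aromatic ring for another; the steps into compound 3 came from open-chain or non-aromatic groups and were modest at most. The expected step is therefore small, a 1.4-fold higher number from compound 3 to compound 4 (0.15 log units; within the scatter), and compound 4 is estimated at 0.25 h, within 0.1 h to 0.6 h.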

Compound 4, half-life: 0.09 h
For compound 4 the middle estimate is 2.8-fold (0.44 log units) above the measured one; measured number outside the range, below it.
By their numbers in this assay, from the lowest: compounds 4, 3 and 1 (each within the scatter of the next, the first and the last beyond it); then compound 2.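

In this assay, one five-membered aromatic ring exchanged for another at this position leaves the two compounds indistinguishable (a 2.0-fold lower number from compound 3 to compound 4 (0.30 log units; within the scatter)). The 4-methyl-1H-imidazol-2-yl group nevertheless separates clearly from the two non-aromatic groups (a 7.9-fold lower number from compound 2 to compound 4 (0.90 log units; beyond the scatter); a 3.6-fold lower number from compound 1 to compound 4 (0.55 log units; beyond the scatter)), whereas the step from compound 1 to compound 3 stayed within the scatter. No measurement shown here bears on the reason for these gaps.

Open, from the compounds shown here alone, is how a plain 1H-imidazol-2-yl, without the methyl, would compare at this position. A carboxylic acid or an amine on a longer chain at this position also remains an open case.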